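This account rests on a few compounds, and the source may have more. Where it says the series, first, only, none or still open, it means among the compounds named here.

Compound 1 `COc1ccccc1Cn1cc(CCCCC[C@@H]2SC[C@@H]3NC(=O)N[C@@H]32)nn1` — in an assay on isolated protein for inhibition of biotin--protein ligase (Homo sapiens), read by scintillation counting, with a stated time of 10 min (a lower number here means a stronger inhibitor, a higher number a weaker inhibitor), compound 1 shows only the limit > 16000 nM.
Compound 2 `Nc1ccccc1Cn1cc(CCCCC[C@@H]2SC[C@@H]3NC(=O)N[C@@H]32)nn1` — in this assay compound 2 shows only the limit > 16000 nM.
Compound 3 `O=C1N[C@H]2[C@H](CS[C@H]2CCCCCc2cn(Cc3ccccc3Br)nn2)N1` — in this assay compound 3 shows only the limit > 16000 nM.

Compound 3 thus stands at the limit in this assay, as do the two other measured compounds (the limit of > 16000 nM in this assay, at which 3 of the 3 values shown sit). Compound 4 `O=C1N[C@H]2[C@H](CS[C@H]2CCCCCc2cn(Cc3cccc(F)c3)nn2)N1` differs from compound 3 by 3-fluorophenyl in place of 2-bromophenyl on a saturated chain carbon bound to an aromatic nitrogen. The measured steps, a step that the two limits leave unreadable from compound 1 to compound 2, a step that the two limits leave unreadable from compound 1 to compound 3 and a step that the two limits leave unreadable from compound 2 to compound 3, each join two limits and carry no readable size, so none of them tells in which direction a change on this ring moves the value. All that bears on the step from compound 3 to compound 4 is that every variant of this ring measured so far remained at the limit. Compound 4 is therefore expected to stay near that limit, with an estimated step that the limit leaves unreadable from compound 3 to compound 4 that may be nothing beyond scatter. For compound 4 the estimate is 20000 nM, ranging from 8000 nM to 60000 nM.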

Compound 4, inhibition constant: > 16000 nM
Compound 4: only a limit was reported (the forecaster's own chance of this, stated with the estimate: 75%); the middle value is on the limit's open side.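

In this assay, among the compounds shown here, compound 4 gives only a limit, as do compound 1, compound 2 and compound 3, so no step among them can be read. From the compounds shown here alone, how strongly any of the four inhibits, and whether any change on this ring moves the value, remains open.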